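The compounds below may be only part of what the source reports. "The series", "measured", "known", "first", "only" and "open" are said of these compounds alone.

Compound 1 `COc1ccc(-c2cc(-c3ccc(F)cc3)nc(NC(=O)N/N=C\c3cccc(Cl)c3)n2)cc1OC` and compound 3 `COc1ccc(-c2cc(-c3ccc(Cl)cc3)nc(NC(=O)N/N=C\c3cccc(Cl)c3)n2)cc1OC` share one core and differ only in that (chloro in place of fluoro on an aromatic carbon). In a functional assay on the whole organism (strain Albino) with Mus musculus as the target, with a stated time of 0.5 h (a lower number here means that less compound is needed, a higher number that more compound is needed for the effect), compound 1 gives 300 mg/kg, and compound 3 gives 100 mg/kg, so a 3.0-fold lower number from compound 1 to compound 3 (0.48 log units; beyond the scatter). Compound 2 `C/C(=N/NC(=O)Nc1nc(-c2ccc(F)cc2)cc(-c2ccc([N+](=O)[O-])cc2)n1)c1ccc(C)cc1` is built on a different core; the difference between the two cores is not broken down here. In this assay compound 2 gives 100 mg/kg, the same number as compound 3 at the digits read. Compound 4 `C/C(=N/NC(=O)Nc1nc(-c2ccc(Cl)cc2)cc(-c2ccc([N+](=O)[O-])cc2)n1)c1ccc(C)cc1` arises from compound 2 by the same change, (chloro in place of fluoro on an aromatic carbon), at the same place. The step expected in this assay is a 2.0-fold lower number from compound 2 to compound 4 (0.30 log units; within the scatter). That expectation rests on compound 1 and compound 3, where a 3.0-fold lower number from compound 1 to compound 3 (0.48 log units; beyond the scatter), held somewhat smaller because compound 2 already stands at 100 mg/kg on another core. Compound 4 is therefore estimated at 50 mg/kg, likely between 25 mg/kg and 150 mg/kg.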

Compound 4, dose for half-maximal effect: 300 mg/kg
Estimate against measurement, compound 4: 6.0-fold (0.78 log units) below; measured number outside the range, above it.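

In this assay, replacing 4-fluorophenyl with 4-chlorophenyl gives a 3.0-fold higher number from compound 2 to compound 4 (0.48 log units; beyond the scatter), so the lower number seen on the other core does not carry over. The two steps run in opposite directions, and the gap between them exceeds what scatter would explain: the same change on two cores in this assay, a 3.0-fold lower number (0.48 log units; beyond the scatter) from compound 1 to compound 3 and a 3.0-fold higher number (0.48 log units; beyond the scatter) from compound 2 to compound 4, 9.0-fold (0.95 log units) apart, beyond the scatter of two such steps This shows that, for these two pairs, the result of the change depends on the core, but it does not show which of the differences between the cores matters, why the direction reverses, or what would happen on a third core.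

The compounds shown carry only fluoro or chloro at this place. Going by these compounds, how a bromo group or an amine there would behave on either core remains open.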